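The source may report more compounds than this note shows. Statements on the series, on what has been measured and on what is new or still open speak of the compounds shown alone.

Working notes on the series. In a functional assay on Caco-2 cells (Homo sapiens), read by MTT assay, with a stated time of 48 h (on this read-out lower numbers stand for stronger inhibition and higher numbers for weaker inhibition), compound 1 `CCn1c(C(=O)NCCN(C)C)ccc1C(CC)(CC)c1ccc(OCC(O)C(C)(C)C)c(C)c1` gives 1300 nM. Compound 2 `CCn1c(C(=O)NCC(OC)OC)ccc1C(CC)(CC)c1ccc(OCC(O)C(C)(C)C)c(C)c1` gives > 50000 nM, which is a limit of the assay and not a number. Its standing rests on that limit alone: the limit of > 50000 nM in this assay, at which 1 of the 2 values shown sits.

The next change leads to compound 3 `CCn1c(C(=O)NCCN)ccc1C(CC)(CC)c1ccc(OCC(O)C(C)(C)C)c(C)c1`, with aminomethyl in place of dimethoxymethyl on a saturated chain carbon bound to an amide-type nitrogen.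

Going by the values given here, one measured step bears on this change at the same place: an at least 38-fold higher number from compound 1 to compound 2 (1.58 log units; beyond the scatter), which is large and beyond the scatter. It put dimethoxymethyl in place of (dimethylamino)methyl, and the new change removes dimethoxymethyl again. Aminomethyl is not (dimethylamino)methyl, however, and no measured step separates those two groups, so the recovery may be only partial. A large step toward lower numbers in this assay is therefore expected, with compound 1 at 1300 nM as the reference point.

The expected change is an at least 16-fold lower number from compound 2 to compound 3 (1.22 log units; beyond the scatter), large and toward stronger inhibition. For compound 3 the estimated value is 3000 nM, with an expected range of 700 nM to 15000 nM.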

Compound 3, half-maximal inhibitory concentration: 1000 nM
Estimate against measurement, compound 3: 3.0-fold (0.48 log units) above, within the range that was stated.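

Aminomethyl in place of dimethoxymethyl, on a saturated chain carbon bound to an amide-type nitrogen, gives an at least 50-fold lower number from compound 2 to compound 3 (1.69 log units; beyond the scatter) in this assay, so the recovery at this place does not depend on (dimethylamino)methyl alone. The two amine-bearing compounds cannot be told apart in this assay, as the step reads a 1.3-fold lower number from compound 1 to compound 3 (0.11 log units; within the scatter), and the methyl groups on that nitrogen are therefore not needed to keep the activity of compound 1 at this place. From the compounds shown here alone, the value of compound 2 is a limit of the assay and not a number, so the true size of the step to compound 3 stays unknown and only its lower bound can be read: the limit of > 50000 nM in this assay, at which 1 of the 3 values shown sits.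

Only aminomethyl and (dimethylamino)methyl stand against dimethoxymethyl here, so the compounds shown cannot tell whether an amine at this place is required or whether other groups, such as hydroxymethyl or a carboxylic acid, would serve as well. Also open, going by these compounds, are a longer chain, such as 3-aminopropyl in place of 2-aminoethyl, and a cyclic amine such as piperidine, which would show how far the tolerance for changes at this place extends.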